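A few compounds are considered here, and "the series" means these few. Any claim that something is new, unique, unknown or untested is made for them only; others in the source may bear on it.

Compound 1 `C=CC1=C(C(=O)NCc2ccc(Cl)cc2)C(c2ccc(OC)cc2)OC1` gives in a functional assay on QGY7701 cells (Homo sapiens) for cytotoxicity, read by MTT assay, with a stated time of 24 h (a higher number here means a weaker inhibitor, a lower number a stronger inhibitor), a limit, > 100000 nM. Compound 2 `C=CC1=C(C(=O)NCc2ccc(C)cc2)C(c2ccc(OC)cc2)OC1` gives 43100 nM. Compound 3 `C=CC1=C(C(=O)Nc2cccc(C)c2)C(c2ccc(F)cc2)OC1` gives 56400 nM.

Compound 2 and compound 3 give numbers within the scatter of each other, while compound 1 gives only a limit. Compound 4 `C=CC1=C(C(=O)Nc2ccccc2)C(c2ccc(F)cc2)OC1` differs from compound 3 by hydrogen in place of methyl on an aromatic carbon. Going by the values given here, the only measured step, an at least 2.3-fold lower number from compound 1 to compound 2 (0.36 log units; beyond the scatter), concerns methyl in place of chloro on the benzyl ring, not the loss of a methyl, so it bears on the present change only loosely. Without a closer precedent, no step beyond the scatter is expected in this assay. Compound 4 is therefore estimated at 60000 nM, within 25000 nM to 150000 nM, a step of a 1.1-fold higher number from compound 3 to compound 4 (0.03 log units; within the scatter) expected.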

Compound 4, half-maximal inhibitory concentration: 46700 nM
Beside the measured number, compound 4's estimate is 1.3-fold (0.11 log units) above it; the measured number falls inside the stated range.
By their numbers in this assay, from the lowest: compounds 2, 4 and 3 (each within the scatter of the next). At a limit, above all of these: compound 1.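

In this assay, hydrogen in place of methyl on an aromatic carbon gives a 1.2-fold lower number from compound 3 to compound 4 (0.08 log units; within the scatter), so at this place the methyl of the 3-methylphenyl group is not needed to hold the reading seen for compound 3. The bare phenyl of compound 4 also stays clear of the limit that only compound 1 reaches: the limit of > 100000 nM in this assay, at which 1 of the 4 values shown sits.

What the compounds shown leave open is whether this place tolerates anything other than a small group, such as an amine, a carboxylic acid or a longer chain. One change from methyl to hydrogen cannot show how the number would respond to those.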